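Methyl for hydrogen on the phenyl of a kinase-type amide

A few compounds are considered here, and "the series" means these few. Any claim that something is new, unique, unknown or untested is made for them only; others in the source may bear on it.

Compound 2 `O=C(Nc1ccc(Oc2ccnc3[nH]ccc23)cc1)c1cc(-c2ccccc2)ncn1`: 240 nM
Compound 1 `O=C(Nc1ccc(Oc2ccnc3[nH]ccc23)cc1)c1cc(-c2ccc(F)cc2)ncn1`: "not active" (no number reported)

For the measured compounds named here, in a functional assay on PC-3 cells (Homo sapiens) for cytotoxicity, read by MTT assay, with a stated time of 72 h (a higher number here means a weaker inhibitor, a lower number a stronger inhibitor), compound 2 gives 240 nM, the only number on record. In the same assay compound 1 was reported as "not active" (no number reported), without a number. Compound 3 `Cc1ccc(-c2cc(C(=O)Nc3ccc(Oc4ccnc5[nH]ccc45)cc3)ncn2)cc1` has not been measured. It differs from compound 2 in one place: methyl in place of hydrogen on an aromatic carbon. Going by the values given here, no step between measured compounds exists to calibrate this change, and compound 1 shows that a change on this ring can remove activity altogether. A modest loss is expected, a 1.9-fold higher number from compound 2 to compound 3 (0.27 log units; within the scatter), with wide uncertainty. Compound 3 is estimated at 450 nM, between 120 nM and 2500 nM.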

Compound 3, half-maximal inhibitory concentration: 9880 nM
Compound 3: the middle estimate sits 22-fold (1.34 log units) below what was measured; measured number above the stated range.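

In this assay, going from phenyl to 4-methylphenyl gives a 41-fold higher number from compound 2 to compound 3 (1.61 log units; beyond the scatter) and so shows that one added methyl, para to a large group, can cost most of the activity. Compound 3 still gives a number, whereas compound 1 was reported as "not active" (no number reported) in the same test. Nothing measured here explains the loss.

Still open, as far as these compounds go, is how other groups at this place would behave, such as a methoxy group, an amine or a carboxylic acid. It is also unknown whether a methyl elsewhere on this ring would do the same.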